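The source may report more compounds than this note shows. Statements on the series, on what has been measured and on what is new or still open speak of the compounds shown alone.

Measured in an ADME assay on RAW264.7 cells (Mus musculus) for cytotoxicity, read by MTT assay, with a stated time of 48 h; a higher number here means a weaker inhibitor, a lower number a stronger inhibitor:
Compound 1 `CCS(=O)(=O)Nc1ccc(NC(=O)c2ccc(C#N)cc2)cc1OC`: 66400 nM
Compound 2 `CS(=O)(=O)Nc1ccc(NC(=O)c2ccc(C#N)cc2)cc1F`: > 250000 nM

The value for compound 2 is a limit of the assay rather than a number. Compound 2 therefore stands at the limit of > 250000 nM in this assay, at which 1 of the 2 values shown sits. Compound 3 `CCS(=O)(=O)Nc1ccc(NC(=O)c2ccc(C#N)cc2)cc1F` differs from compound 2 by methyl in place of hydrogen on a saturated chain carbon bound to a sulfonyl sulfur. For the measured compounds named here, no measured pair isolates this change, so its size in this assay cannot be read from the data; the expectation is a step no larger than the usual scatter, in either direction. Compound 3 is expected to give about 180000 nM, in a range from 50000 nM to 400000 nM. That expectation corresponds to an estimated step of an at least 1.3-fold lower number from compound 2 to compound 3 (0.14 log units; that floor lies within the scatter).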

Compound 3, half-maximal inhibitory concentration: 107000 nM
The estimate for compound 3 lay 1.7-fold (0.23 log units) above the measured number, and the stated range covers the measured number.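

In this assay, methanesulfonamido changing to (ethylsulfonyl)amino gives an at least 2.3-fold lower number from compound 2 to compound 3 (0.36 log units; beyond the scatter), so adding this methyl on a saturated chain carbon bound to a sulfonyl sulfur moves the read-out beyond the usual scatter. The value for compound 2 is a limit of the assay: the limit of > 250000 nM in this assay, at which 1 of the 3 values shown sits.

Fluoro in place of methoxy on an aromatic carbon gives a 1.6-fold higher number from compound 1 to compound 3 (0.21 log units; within the scatter), a step within the scatter, so this assay does not separate these two compounds.

From the compounds shown here alone, whether a longer chain such as propyl on the sulfonyl sulfur would move the number further remains open. So does how an amine on that aromatic carbon would read.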